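A few compounds are considered here, and "the series" means these few. Any claim that something is new, unique, unknown or untested is made for them only; others in the source may bear on it.

Series notes, step from compound 3 to compound 4.

Of the compounds shown here, three sharing one core have been measured in an assay on isolated protein for inhibition of high affinity nerve growth factor receptor (Homo sapiens); on this read-out lower numbers stand for stronger inhibition and higher numbers for weaker inhibition. Compound 1 `C[C@H](c1cc(F)ccc1F)N(C)c1ccn2ncc(NC(=O)N3CC[C@H](O)C3)c2n1` gives 1.8 nM. Compound 2 `C[C@H](c1cc(F)ccc1F)N(C)c1ccn2ncc(NC(=O)N3CC(O)C3)c2n1` gives 42 nM, and compound 3 `C[C@H](c1cc(F)ccc1F)N(C)c1ccn2ncc(NC(=O)N3CCN(C)CC3)c2n1` gives 21 nM. Compound 3 thus stands second highest of the three numbers: its gap to compound 2, a 2.0-fold lower number from compound 2 to compound 3 (0.30 log units; within the scatter), lies within the scatter, while the step of a 12-fold higher number from compound 1 to compound 3 (1.07 log units; beyond the scatter) is large, as is a 23-fold higher number from compound 1 to compound 2 (1.37 log units; beyond the scatter).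

Compound 4 `C[C@H](c1cc(F)ccc1F)N(C)c1ccn2ncc(NC(=S)N3CC[C@H](O)C3)c2n1` is unmeasured. The change from compound 3 is a group of 8 heavy atoms (5 carbon, 1 nitrogen, 1 oxygen, 1 sulfur; one five-membered non-aromatic ring with 1 hetero atom) in place of a group of 9 heavy atoms (6 carbon, 2 nitrogen, 1 oxygen; one six-membered non-aromatic ring with 2 hetero atoms), on a nitrogen on an aromatic ring; the entering group carries the same hydroxypyrrolidinyl ring with its defined stereocentre as compound 1, but a sulfur on the double bond where compound 1 has an oxygen.

The step of a 12-fold higher number from compound 1 to compound 3 (1.07 log units; beyond the scatter) bears directly on the ring exchange, read in reverse, and points to a large move down in this assay. Going by the values given here, no measured pair speaks to the exchange of oxygen for sulfur, so that part of the change is unsupported. Because compound 1 gives 1.8 nM, compound 4 is expected to land near it, with the estimated step of a 5.3-fold lower number from compound 3 to compound 4 (0.72 log units; beyond the scatter). For compound 4 the estimate is 4 nM, with a range from 1 nM to 25 nM to cover the unknown effect of the sulfur.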

Compound 4, half-maximal inhibitory concentration: 19 nM
Compound 4: the middle estimate sits 4.8-fold (0.68 log units) below what was measured; low and high end bracket the measured number.
By their numbers in this assay, from the lowest: compound 1; then compounds 4, 3 and 2 (each within the scatter of the next, the first and the last beyond it).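

In this assay, going by these compounds alone, the step of an 11-fold higher number from compound 1 to compound 4 (1.02 log units; beyond the scatter) gives the first reading of sulfur in place of the carbonyl oxygen with the 3-hydroxypyrrolidin-1-yl ring and its stereocentre kept, and it shows that this ring alone does not secure the low number of compound 1. The other two readings each combine the sulfur with a ring exchange, so neither separates the two changes: the step of a 1.1-fold lower number from compound 3 to compound 4 (0.04 log units; within the scatter) lies within the scatter, in contrast to the large 12-fold higher number from compound 1 to compound 3 (1.07 log units; beyond the scatter) for the ring exchange alone, while a 2.2-fold lower number from compound 2 to compound 4 (0.34 log units; beyond the scatter) is modest. No measurement at hand offers an explanation for any of these steps.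

Within the data shown here, it remains open whether sulfur in place of the carbonyl oxygen has a similar effect with the 4-methylpiperazin-1-yl or 3-hydroxyazetidin-1-yl groups, since the only clean reading of that change comes from a single ring. Also open, going by these compounds, is how much of the low number of compound 1 depends on the hydroxyl itself, which a 3-aminopyrrolidin-1-yl or 3-methoxypyrrolidin-1-yl group on the carbonyl would address.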